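Closing the Sulfonamide into a Ring

A few compounds are considered here, and "the series" means these few. Any claim that something is new, unique, unknown or untested is made for them only; others in the source may bear on it.

Three compounds have been measured in an assay on CHO-K1 cells for displacement of a labelled ligand from melanin-concentrating hormone receptor 1 (Homo sapiens), read by scintillation proximity assay, with a stated time of 2 h; on this read-out higher numbers stand for weaker inhibition and lower numbers for stronger inhibition:

Compound 1, `Cc1nc(N2CCC(NS(=O)(=O)N(C)C)CC2)nc2ccc(NC(=O)/C=C/c3ccc(OC(F)(F)F)cc3)cc12`: 105 nM
Compound 2, `CCCC1(O)CCN(c2nc(C)c3cc(NC(=O)/C=C/c4ccc(Cl)cc4)ccc3n2)CC1`: 245 nM
Compound 3, `Cc1nc(N2CCC(O)(C3CCC3)CC2)nc2ccc(NC(=O)/C=C/c3ccc(Cl)cc3)cc12`: 206 nM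

Compound 1 sits at the low end of these three numbers. Its gap to compound 3 lies within the usual scatter, so the two cannot be told apart; its gap to compound 2 lies beyond the scatter.

Compound 4, `Cc1nc(N2CCC(N3CCCS3(=O)=O)CC2)nc2ccc(NC(=O)/C=C/c3ccc(OC(F)(F)F)cc3)cc12`, has not yet been measured. It differs from compound 1 in one place: a group of 7 heavy atoms (3 carbon, 1 nitrogen, 2 oxygen, 1 sulfur; one five-membered non-aromatic ring with 2 hetero atoms) in place of a group of 7 heavy atoms (2 carbon, 2 nitrogen, 2 oxygen, 1 sulfur; no ring), on a saturated ring carbon. Going by the values given here, the only step measured so far is a 1.2-fold lower number from compound 2 to compound 3 (0.08 log units; within the scatter), and it concerns the group on a saturated ring carbon in compounds that carry a hydroxyl there and a chloro-substituted cinnamamide, not the sulfur-bearing group of compound 1. Among the compounds with values here, it shows only that a change on that ring carbon can pass within the scatter. Within the data shown here, no measured step alters a sulfonamide, so nothing here points in a particular direction.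

The step from compound 1 to compound 4 is therefore expected to stay within or near the scatter, a 1.4-fold higher number from compound 1 to compound 4 (0.15 log units; within the scatter). Compound 4 is expected to give about 150 nM in this assay, in a range from 50 nM to 450 nM.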

Compound 4, half-maximal inhibitory concentration: 4 nM
Compound 4: middle estimate off by 38-fold (1.57 log units), on the high side; the measured number lies below the stated range.
By their numbers in this assay, from the lowest: compound 4; then compounds 1, 3 and 2 (each within the scatter of the next, the first and the last beyond it).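

In this assay, going by these compounds alone, replacing the open (dimethylsulfamoyl)amino group with a five-membered non-aromatic ring with 2 hetero atoms gives a 26-fold lower number from compound 1 to compound 4 (1.42 log units; beyond the scatter), whereas the only earlier step on a saturated ring carbon, a 1.2-fold lower number from compound 2 to compound 3 (0.08 log units; within the scatter), stayed within the scatter. This position can therefore respond strongly to a change, even when the leaving and entering groups both have 7 heavy atoms and 2 hydrogen-bond acceptors. What the structures do show is that the entering group has a ring, a carbon in place of a nitrogen, and 0 hydrogen-bond donors rather than 1, but no measurement here links the step to any one of these differences.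

The compounds shown leave open whether the ring itself matters or whether an open chain without the hydrogen-bond donor would do as well, and how a six-membered ring, a plain amine or a carboxylic acid would fare on this ring carbon. They also leave open whether the same ring would give a similar step alongside the chloro-substituted cinnamamide of compound 3.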